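Working notes: from compound 3 to compound 4

This account rests on a few compounds, and the source may have more. Where it says the series, first, only, none or still open, it means among the compounds named here.

Compound 1 `COc1cccc(CN2C(=O)CN(C(=O)c3cc4cc(OC)ccc4[nH]3)C[C@@H]2COCc2ccccc2)c1`: > 10000 nM (a limit)
Compound 2 `COc1cccc(CN2C(=O)CN(C(=O)c3cc4cc(OC)ccc4[nH]3)C[C@@H]2CCc2ccccc2)c1`: 4500 nM
Compound 3 `COc1ccc2[nH]c(C(=O)N3CC(=O)N(Cc4ccccc4)[C@@H](N4[C@H](C)CCC[C@@H]4C)C3)cc2c1`: 1400 nM

All three values come from an ADME assay on Vero cells (Chlorocebus sabaeus) for cytotoxicity, with a stated time of 7 days; a lower number here means that less compound is tolerated, a higher number that more compound is tolerated. Compound 1 stands at a limit: the limit of > 10000 nM in this assay, at which 1 of the 3 values shown sits. Of the two actual numbers, compound 3 has the lower, 1400 nM, and compound 2 lies higher at 4500 nM. Compound 4 `COc1ccc2[nH]c(C(=O)N3CC(=O)N(Cc4ccccc4)[C@@H](CN4CC5CCCCC5C4)C3)cc2c1` differs from compound 3 by a group of 10 heavy atoms (9 carbon, 1 nitrogen; one five-membered non-aromatic ring with 1 hetero atom, one six-membered non-aromatic ring of carbon only) in place of a group of 8 heavy atoms (7 carbon, 1 nitrogen; one six-membered non-aromatic ring with 1 hetero atom), on a saturated ring carbon. Going by the values given here, the only measured step, an at least 2.2-fold lower number from compound 1 to compound 2 (0.34 log units; beyond the scatter), is a different group exchange and bears on this change only loosely. It gives no firm direction for this assay, so the estimated 1.4-fold higher number from compound 3 to compound 4 (0.15 log units; within the scatter) is expected to stay within the scatter. Compound 4 is estimated at 2000 nM, with an expected range of 700 nM to 6000 nM.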

Compound 4, half-maximal cytotoxic concentration: 8200 nM
For compound 4 the middle estimate is 4.1-fold (0.61 log units) below the measured one, and the stated range ends below it.
By their numbers in this assay, from the lowest: compound 3; then compounds 2 and 4 (each within the scatter of the next). At a limit, above all of these: compound 1.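

In this assay, the group on this saturated ring carbon alone moves the number beyond the scatter: the fused two-ring group in place of 2,6-dimethylpiperidin-1-yl gives a 5.9-fold higher number from compound 3 to compound 4 (0.77 log units; beyond the scatter). Both groups count 0 hydrogen-bond donors, 1 hydrogen-bond acceptor and no net charge, so these counts do not separate them. Nothing measured here accounts for the step. Going by these compounds alone, with only two groups compared at this carbon, it remains open whether size or ring shape tracks the change. As far as these compounds go, how a morpholine or a carboxylic acid would read here also remains open.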